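Compound 3 to compound 4: a methyl on the phenyl

The compounds below may be only part of what the source reports. "The series", "measured", "known", "first", "only" and "open" are said of these compounds alone.

In a functional assay on MCF7 cells (Homo sapiens) for cytotoxicity, read by MTT assay, with a stated time of 48 h (a higher number here means a weaker inhibitor, a lower number a stronger inhibitor), compound 3 `S=C(N/N=C\c1ccnc2ccccc12)Nc1ccccc1` gives 1070 nM. Compound 1 `COc1ccc(NC(=S)N/N=C\c2ccnc3ccccc23)cc1` gives 990 nM and compound 2 `Fc1ccc(NC(=S)N/N=C\c2ccnc3ccccc23)cc1` gives 1100 nM, so compound 3 stands within the scatter of both. Compound 4 `Cc1ccc(NC(=S)N/N=C\c2ccnc3ccccc23)cc1` has methyl in place of hydrogen on an aromatic carbon, para to a large group: methyl in place of hydrogen on an aromatic carbon. Two measured steps also change the group on an aromatic carbon: a 1.1-fold higher number from compound 1 to compound 3 (0.03 log units; within the scatter) and a 1.0-fold lower number from compound 2 to compound 3 (0.01 log units; within the scatter). Both lie within the scatter, though neither involves a methyl. On that basis, no step beyond the scatter is expected in this assay. The expected step is a 1.0-fold lower number from compound 3 to compound 4 (0.01 log units; within the scatter). Compound 4 is estimated at 1050 nM, with an expected range of 600 nM to 1800 nM.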

Compound 4, half-maximal inhibitory concentration: 980 nM
The estimate for compound 4 lay 1.1-fold (0.03 log units) above the measured number; the measured number falls inside the stated range.
By their numbers in this assay, from the lowest: compounds 4, 1, 3 and 2 (each within the scatter of the next).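

In this assay methyl gives a 1.1-fold lower number from compound 3 to compound 4 (0.04 log units; within the scatter) against hydrogen, a 1.1-fold lower number from compound 2 to compound 4 (0.05 log units; within the scatter) against fluoro and a 1.0-fold lower number from compound 1 to compound 4 (0.00 log units; within the scatter) against methoxy, so a carbon substituent at this place, para to a large group, also leaves the number within the scatter. All four groups tried here now read alike in this assay. Nothing available explains this lack of separation.

As far as these compounds go, whether an amine, a carboxylic acid or a longer chain at this place would give a step beyond the scatter remains open. The compounds shown vary only this one place, so the contribution of the shared core remains unread.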